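This account rests on a few compounds, and the source may have more. Where it says the series, first, only, none or still open, it means among the compounds named here.

Measured so far in a functional assay on CCRF-CEM cells for antagonist activity at C-X-C chemokine receptor type 4 (Homo sapiens), read by calcium flux, with stated times of 25 min and 90 s; a lower number here means a stronger inhibitor, a higher number a weaker inhibitor:
compound 1 `c1ccc2c(c1)CN[C@@H](CN(CCC1CCNCC1)[C@H]1CCCc3cccnc31)C2` gives 150 nM;
compound 2 `CN1CCN(CCCN(C[C@H]2Cc3ccccc3CN2C)[C@H]2CCCc3cccnc32)CC1` gives 536 nM;
compound 3 `c1cnc2c(c1)CCC[C@@H]2N(CCCN1CCNCC1)Cc1nc2ccccc2[nH]1` gives 45 nM.

On these three numbers compound 1 sits second highest: compound 3 lies lower by a gap beyond the scatter, and compound 2 lies higher by a gap also beyond the scatter. Going by the values given here, no single-point step between measured compounds is available.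

Compound 4 `c1ccc2c(c1)CN[C@@H](CN(CC[C@H]1CCCNC1)[C@H]1CCCc3cccnc31)C2` is not yet measured. It differs from compound 1 by piperidin-3-yl in place of piperidin-4-yl on a saturated chain carbon, two bonds along the chain from an amine nitrogen. The change keeps the same atoms, joined differently, with one defined stereocentre entering. Among the compounds with values here, no measured pair isolates this kind of change, so the expected step from compound 1 to compound 4 is small, in either direction, likely within scatter: a 1.3-fold higher number from compound 1 to compound 4 (0.12 log units; within the scatter). For compound 4 the estimate in this assay is 200 nM, expected between 70 nM and 600 nM.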

Compound 4, half-maximal inhibitory concentration: 16 nM
Estimate against measurement, compound 4: 13-fold (1.10 log units) above, outside the stated range (below it).
By their numbers in this assay, from the lowest: compound 4; then compound 3; then compound 1; then compound 2.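

In this assay, piperidin-3-yl in place of piperidin-4-yl on this saturated chain carbon gives a 9.4-fold lower number from compound 1 to compound 4 (0.97 log units; beyond the scatter) and makes a clear difference beyond the scatter. Going by these compounds alone, the same atoms, joined differently, therefore shift the number substantially at a place where no earlier pair offered a reading. Nothing available accounts for the size of this step. Still open, going by these compounds, is whether the opposite configuration at the new stereocentre gives a similar number. Also open, on these data alone, is whether a pyrrolidin-3-yl or piperidin-2-yl group at this place, or a longer chain, would hold it.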